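Second fluorine on the diaryl indole-free core: expected cytotoxicity

The compounds below may be only part of what the source reports. "The series", "measured", "known", "first", "only" and "open" are said of these compounds alone.

Measured so far:
- compound 1, `CC(=O)c1cc(-c2ccccc2)cc2cc(-c3ccccc3)[nH]c12`, 51.4%
- compound 2, `CC(=O)c1cc(-c2ccc(F)cc2)cc2cc(-c3ccccc3)[nH]c12`, 24.8%
- compound 3, `CC(=O)c1cc(-c2ccccc2)cc2cc(-c3ccc(F)cc3)[nH]c12`, 68.3%

All three were tested in a functional assay on HeLa cells (Homo sapiens) for cytotoxicity, read by MTT assay, with a stated time of 2 days, tested at 100 uM; a lower number here means a stronger effect, a higher number a weaker effect of the compound at the concentration tested. Compound 3 gives the highest number of the three, standing a number 16.9 percentage points higher from compound 1 to compound 3 (beyond the scatter) above compound 1 and further still above compound 2. In this series a high number means the cells were barely affected, so compound 3 is the weakest of the three at the concentration tested.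

Compound 4, `CC(=O)c1cc(-c2ccc(F)cc2)cc2cc(-c3ccc(F)cc3)[nH]c12`, has not yet been measured. It differs from compound 3 by fluoro in place of hydrogen on an aromatic carbon. The phenyl ring that is altered here is the same one that was altered in going from compound 1 to compound 2, where the change brought a number 26.6 percentage points lower from compound 1 to compound 2 (beyond the scatter). That step is the one that bears directly on the present one; the other step, from compound 1 to compound 3, changed the other phenyl ring. Going by the values given here, the single comparable step was a modest drop beyond the scatter, so a drop of similar size is expected here: a number 26.3 percentage points lower from compound 3 to compound 4 (beyond the scatter). Among the compounds with values here, compound 4 is therefore expected to give about 42%, with a likely range from 25% to 62%, since only one step supports the estimate.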

Compound 4, a percentage reported as activity, at one concentration (the size of the read-out at that concentration, not a potency): 9.31%
Compound 4: middle estimate off by 32.7 percentage points, on the high side; measured number below the stated range.
By their numbers in this assay, from the lowest: compound 4; then compound 2; then compound 1; then compound 3.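

In this assay, swapping phenyl for 4-fluorophenyl lowers the number on both cores, so the direction of this change holds across the two pairs, but its size does not (here a number 59 percentage points lower from compound 3 to compound 4 (beyond the scatter)). The size of the step depends on whether the other phenyl ring already carries a fluorine, so the two rings cannot be treated as independent: the same change on two cores in this assay, a number 26.6 percentage points lower (beyond the scatter) from compound 1 to compound 2 and a number 59 percentage points lower (beyond the scatter) from compound 3 to compound 4, 32.4 percentage points apart, beyond the scatter of two such steps. Seen from the other ring, the same dependence appears as a change of direction, since a fluorine on that ring raised the number on the core of compound 1 but lowers it once 4-fluorophenyl is in place (there a number 15.5 percentage points lower from compound 2 to compound 4 (beyond the scatter)): the same change on two cores in this assay, a number 16.9 percentage points higher (beyond the scatter) from compound 1 to compound 3 and a number 15.5 percentage points lower (beyond the scatter) from compound 2 to compound 4, 32.4 percentage points apart, beyond the scatter of two such steps.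

From the compounds shown here alone, it remains open whether a chloro, a methoxy or an amino group at this position would lower the number as fluoro does and would depend on the other ring in the same way. Each number also describes the effect at a single concentration rather than a potency, and these four compounds do not show why the two rings influence each other.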